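The compounds below may be only part of what the source reports. "The series", "measured", "known", "first", "only" and "open" are said of these compounds alone.

Of the compounds shown here, three built on one shared core have been tested in a functional assay on the whole organism (strain albino) with Mus musculus as the target, at a dose of 100 mg/kg by the intraperitoneal route; a lower number here means less inhibition, a higher number more inhibition at the dose given (going by the name of the read-out). Compound 1 `CCc1nc2ccccc2c(=O)n1NC(=O)Nc1ccc([N+](=O)[O-])cc1` gives 41% in this assay. Within the data shown here, compound 3 `CCc1nc2ccccc2c(=O)n1NC(=O)Nc1ccccc1` gives 54%, and the single change between them, hydrogen in place of nitro on an aromatic carbon, reads a number 13 percentage points higher from compound 1 to compound 3 (beyond the scatter). Compound 2 `Cc1ccc(NC(=O)Nn2c(-c3ccccc3)nc3ccccc3c2=O)cc1` gives 54% in this assay, level with compound 3 at the digits shown and, together with it, the highest of the three numbers, while compound 1 sits lower by a margin beyond the scatter.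

Compound 4 `Cc1cccc(NC(=O)Nn2c(-c3ccccc3)nc3ccccc3c2=O)c1` differs from compound 2 only by 3-methylphenyl in place of 4-methylphenyl on an amide-type nitrogen. Among the measured compounds shown here, no measured step bears directly on this change: the one step on record, a number 13 percentage points higher from compound 1 to compound 3 (beyond the scatter), concerns hydrogen in place of nitro, a different kind of alteration, and here the leaving and entering groups have the same atoms joined differently. With nothing to push the number either way, the step expected is a number 2 percentage points lower from compound 2 to compound 4 (within the scatter), that is, none beyond the scatter. Compound 4 is therefore estimated to give 52%, within a range from 38% to 66%.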

Compound 4, a percentage reported as inhibition, in the whole organism at one dose (the size of the read-out at that dose, not a potency): 59%
Compound 4: the middle estimate sits 7 percentage points below what was measured, and the stated range covers the measured number.
By their numbers in this assay, from the lowest: compound 1; then compounds 2, 3 and 4 (each within the scatter of the next).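

Putting 3-methylphenyl in place of 4-methylphenyl on an amide-type nitrogen gives a number 5 percentage points higher from compound 2 to compound 4 (within the scatter) in this assay. The earlier step replaced a nitro group with hydrogen, whereas this pair tests only a rearrangement of the same atoms, and in this pair that rearrangement leaves no difference that can be told from the scatter of repeated measurements. Nothing measured here gives a reason for the result, and none is needed for a step of this size.

The compounds shown leave open whether a different group on this phenyl ring, such as a methoxy group, a chlorine atom or an amine, would read any differently from methyl. With only one dose tested, they also cannot show whether the two methylphenyl compounds would still match at other doses.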